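Swapping the azetidine on the carbonyl of compound 2

A few compounds are considered here, and "the series" means these few. Any claim that something is new, unique, unknown or untested is made for them only; others in the source may bear on it.

Measured so far in a physicochemical assay for solubility, measured as kinetic solubility; on this read-out lower numbers stand for lower solubility and higher numbers for higher solubility:
- Compound 1 `Cc1cc2c(Oc3cnc(C(=O)N4CC(C)(C)C4)cn3)cc(C(=O)Nc3cnccn3)cc2o1`: 78000 nM
- Compound 2 `COC1CN(C(=O)c2cnc(Oc3cc(C(=O)Nc4cnccn4)cc4oc(C)cc34)cn2)C1`: 158000 nM

Going by the values given here, of the two measured compounds, compound 2 holds the higher number at 158000 nM, and the only other number is that of compound 1 at 78000 nM. The next compound to be read in this assay is compound 3 `Cc1cc2c(Oc3cnc(C(=O)N4CC(C)(O)C4)cn3)cc(C(=O)Nc3cnccn3)cc2o1`, which differs from compound 2 by one group: 3-hydroxy-3-methylazetidin-1-yl in place of 3-methoxyazetidin-1-yl on a carbonyl carbon. In words, 3-hydroxy-3-methylazetidin-1-yl stands in place of 3-methoxyazetidin-1-yl on a carbonyl carbon. The two compounds have the same atoms, joined differently.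

Among the compounds with values here, only one measured step bears on this change. It is a 2.0-fold higher number from compound 1 to compound 2 (0.31 log units; beyond the scatter), made at the same place, with 3-methoxyazetidin-1-yl in place of 3,3-dimethylazetidin-1-yl. Within the data shown here, no measured step shows the exact exchange now in question, so the direction remains open. With that single modest step as the guide, the expected step is a 1.1-fold lower number from compound 2 to compound 3 (0.02 log units; within the scatter), which means none beyond the scatter. The estimate for compound 3 is 150000 nM, with an expected range from 75000 nM to 300000 nM.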

Compound 3, solubility: 137000 nM
Compound 3: middle estimate off by 1.1-fold (0.04 log units), on the high side; the range from low to high includes it.
By their numbers in this assay, from the lowest: compounds 1, 3 and 2 (each within the scatter of the next, the first and the last beyond it).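

In this assay the exchange of 3-methoxyazetidin-1-yl for 3-hydroxy-3-methylazetidin-1-yl on the carbonyl carbon keeps the same atoms and brings in a hydrogen-bond donor, and it gives a 1.2-fold lower number from compound 2 to compound 3 (0.06 log units; within the scatter), so at this position the two groups cannot be told apart in this read-out. Hydroxy in place of methyl on a saturated ring carbon gives a 1.8-fold higher number from compound 1 to compound 3 (0.24 log units; within the scatter), which also stays inside the usual scatter. The three compounds therefore do not form clear tiers: only compound 1 and compound 2 are separated beyond the scatter, while compound 3 lies within the scatter of each, so these three azetidine amides occupy a narrow band.

Nothing available here gives a reason for these readings. Going by these compounds, whether an amine or a carboxylic acid on the azetidine, or a longer chain in place of the methyl on the ring carbon, would move the number outside this band remains open.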